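Furan Replacement at the Saturated Ring Carbon

This account rests on a few compounds, and the source may have more. Where it says the series, first, only, none or still open, it means among the compounds named here.

Going by the values given here, compound 2 `COc1ccc2ccccc2c1C1C(C#N)=C(N)N(c2ccc(S(N)(=O)=O)cc2)C2=C1C(=O)CCC2` is the stronger of the two measured members: in a functional assay on Ehrlich cells (Mus musculus) for antiproliferative activity, read by trypan blue exclusion, with a stated time of 2 h, tested at 10 ug/mL (a higher number here means a stronger effect of the compound at the concentration tested, a lower number a weaker effect), compound 2 gives 40%, whereas compound 1 `COc1ccccc1C1C(C#N)=C(N)N(c2ccc(S(N)(=O)=O)cc2)C2=C1C(=O)CCC2` gives 0% in this assay. Among the compounds with values here, the single measured step, a number 40 percentage points higher from compound 1 to compound 2 (beyond the scatter), is the only guide available. Compound 3 `N#CC1=C(N)N(c2ccc(S(N)(=O)=O)cc2)C2=C(C(=O)CCC2)C1c1ccco1` differs from compound 2 in one place: furan-2-yl in place of 2-methoxynaphthalen-1-yl on a saturated ring carbon. Within the data shown here, no measured step has furan-2-yl entering at this position, so the expectation rests on the one change seen, in which the larger bicyclic group was the one giving the higher number. Compound 3 returns to a smaller aromatic group, so a drop is expected, estimated as a number 30 percentage points lower from compound 2 to compound 3 (beyond the scatter), in the direction of compound 1 but with wide uncertainty. Compound 3 is therefore expected to give about 10% in this assay, within 0% to 40%.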

Compound 3, a percentage reported as activity, at one concentration (the size of the read-out at that concentration, not a potency): 0%
Beside the measured number, compound 3's estimate is 10 percentage points above it, and the stated range covers the measured number.
By their numbers in this assay, from the lowest: compounds 1 and 3 (each within the scatter of the next); then compound 2.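

Step notes: in this assay, the change from 2-methoxynaphthalen-1-yl to furan-2-yl on the saturated ring carbon gives a number 40 percentage points lower from compound 2 to compound 3 (beyond the scatter), while the change from 2-methoxyphenyl to furan-2-yl gives no change at the digits printed from compound 1 to compound 3 (within the scatter). Among the three groups at this position, only 2-methoxynaphthalen-1-yl gives a read-out beyond the scatter of the other two, so replacing the methoxyphenyl group with a five-membered aromatic ring with one hetero atom does not restore the effect. No supporting data bear on why these groups differ.

Still open, from the compounds shown here alone, is whether the effect of compound 2 depends on the second aromatic ring, the methoxy group or their combination; a plain naphthalen-1-yl group at this carbon would separate these. The read-out also comes from a single concentration, so potency across the series remains undefined.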